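This account rests on a few compounds, and the source may have more. Where it says the series, first, only, none or still open, it means among the compounds named here.

In a functional assay on A549 cells (Homo sapiens) for antiproliferative activity, read by MTT assay, with a stated time of 48 h (a higher number here means a weaker inhibitor, a lower number a stronger inhibitor), compound 1 `COC/C1=C/C[C@](C)(CCC=C(C)C)/C=C/[C@@H](OC(=O)C=C(C)C)[C@](C)(O)/C=C/C1=O` gives 3950 nM, and compound 2 `CC(C)=CCC[C@]1(C)/C=C/[C@@H](OC(=O)C=C(C)C)[C@](C)(O)/C=C/C(=O)/C(CN(C)C)=C\C1` gives 590 nM, the lower of the two numbers. Compound 3 `CC[Si](CC)(CC)C/C1=C/C[C@](C)(CCC=C(C)C)/C=C/[C@@H](OC(=O)C=C(C)C)[C@](C)(O)/C=C/C1=O` differs from compound 2 by a group of 7 heavy atoms (6 carbon, 1 silicon; no ring) in place of a group of 3 heavy atoms (2 carbon, 1 nitrogen; no ring), on a saturated chain carbon bound to a double-bonded ring carbon. Within the data shown here, only one measured step bears on this place: dimethylamino replacing methoxy gave a 6.7-fold lower number from compound 1 to compound 2 (0.83 log units; beyond the scatter). Among the measured compounds shown here, with dimethylamino gone, much of that gain may be lost, although no measured compound carries silicon. The expected change is therefore a moderate rise, a 4.2-fold higher number from compound 2 to compound 3 (0.63 log units; beyond the scatter). For compound 3 the estimated value is 2500 nM, with an expected range of 700 nM to 8000 nM.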

Compound 3, half-maximal inhibitory concentration: 3100 nM
Beside the measured number, compound 3's estimate is 1.2-fold (0.09 log units) below it; low and high end bracket the measured number.
By their numbers in this assay, from the lowest: compound 2; then compounds 3 and 1 (each within the scatter of the next).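

In this assay, the group of 7 heavy atoms with silicon does not hold on to the gain seen with dimethylamino, giving a 5.3-fold higher number from compound 2 to compound 3 (0.72 log units; beyond the scatter) at this saturated chain carbon. Set against methoxy, the same group gives a 1.3-fold lower number from compound 1 to compound 3 (0.11 log units; within the scatter) and so cannot be ranked against it, which leaves dimethylamino as the one group of the three that stands apart. The data offer no measured explanation for this.

As far as these compounds go, whether another amine, such as diethylamino or morpholine, would match dimethylamino here remains open, as does the outcome with a carboxylic acid.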